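The source may hold more compounds than are shown below. What is called first, only, known or untested is meant among the compounds shown, and "the series" means these compounds.

In a functional assay on the whole organism (uterus) with Rattus norvegicus as the target, tested at 10 uM (a higher number here means a weaker effect of the compound at the concentration tested, a lower number a stronger effect), compound 1 `Oc1nc(NCc2ccccc2)nc2ccc(I)cc12` gives 106%, while compound 2 `Oc1nc(NCc2ccccc2)nc2ccc(Br)cc12` gives 76.8%. The shift was a number 29.2 percentage points lower from compound 1 to compound 2 (beyond the scatter), brought by bromo in place of iodo on an aromatic carbon. Among the compounds with values here, compound 2 thus stands at the lower of the two numbers so far. Compound 3 `Oc1nc(NCc2ccccc2)nc2ccccc12` carries hydrogen in place of bromo on an aromatic carbon. Within the data shown here, only the step between compound 1 and compound 2 bears on this change; it was modest and beyond the scatter. A further downward shift, similar or smaller, seems the likeliest outcome. The step expected is a number 8.8 percentage points lower from compound 2 to compound 3 (within the scatter). Compound 3 is estimated at 68%, between 40% and 100%.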

Compound 3, a percentage reported as activity, at one concentration (the size of the read-out at that concentration, not a potency): 97.2%
For compound 3 the middle estimate is 29.2 percentage points below the measured one, and the stated range covers the measured number.
By their numbers in this assay, from the lowest: compound 2; then compounds 3 and 1 (each within the scatter of the next).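

Taking the bromo away does not extend the downward shift: in this assay the change runs the other way, with a number 20.4 percentage points higher from compound 2 to compound 3 (beyond the scatter). Hydrogen in place of iodo gives a number 8.8 percentage points lower from compound 1 to compound 3 (within the scatter), so at this position compound 2 alone stands apart, and the two other compounds cannot be told apart. No measured evidence explains why bromo differs here .

As far as these compounds go, whether fluoro, chloro, methoxy or an amine at this place would match bromo or hydrogen remains open. So does whether the effect of bromo persists when the benzyl group changes.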